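The source may hold more compounds than are shown below. What is called first, only, known or untested is meant among the compounds shown, and "the series" means these compounds.

Measured in a functional assay on EBC-1 cells (Homo sapiens) for antiproliferative activity, with a stated time of 72 h; a lower number here means a stronger inhibitor, a higher number a weaker inhibitor:
Compound 1 `Cn1cc(-c2cc(F)c3ncc(Cc4ccc5ncccc5c4)n3c2)cn1`: 0.27 nM
Compound 2 `N#Cc1ccc(-c2cc(F)c3ncc(Cc4ccc5ncccc5c4)n3c2)cn1`: 189 nM
Compound 3 `N#Cc1cccc(-c2cc(F)c3ncc(Cc4ccc5ncccc5c4)n3c2)c1`: 107 nM

The three compounds share one core and differ only in a single aromatic group. Compound 3 belongs to the upper pair of numbers: there is a 400-fold higher number from compound 1 to compound 3 (2.60 log units; beyond the scatter), and there is a 1.8-fold lower number from compound 2 to compound 3 (0.25 log units; within the scatter).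

Compound 4 `Fc1cc(F)cc(-c2cc(F)c3ncc(Cc4ccc5ncccc5c4)n3c2)c1` keeps the shared core and carries 3,5-difluorophenyl in place of 3-cyanophenyl on an aromatic carbon. Going by the values given here, no measured step makes this exact exchange. The closest one replaces 6-cyanopyridin-3-yl with 3-cyanophenyl, and it stays within the scatter. The two large steps, a 700-fold higher number from compound 1 to compound 2 (2.85 log units; beyond the scatter) and a 400-fold higher number from compound 1 to compound 3 (2.60 log units; beyond the scatter), both leave 1-methyl-1H-pyrazol-4-yl, a group compound 4 does not carry. A step beyond the scatter is therefore not expected in this assay, in either direction. Compound 1 also has no nitrile, so the range is kept wide, especially toward lower numbers.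

The expected step is a 1.1-fold lower number from compound 3 to compound 4 (0.03 log units; within the scatter). Compound 4 is estimated at 100 nM, with an expected range of 15 nM to 400 nM.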

Compound 4, half-maximal inhibitory concentration: 790 nM
For compound 4 the middle estimate is 7.9-fold (0.90 log units) below the measured one; measured number above the stated range.
By their numbers in this assay, from the lowest: compound 1; then compounds 3 and 2 (each within the scatter of the next); then compound 4.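

Going by these compounds alone, until now the only groups compared away from 1-methyl-1H-pyrazol-4-yl were the two nitrile-bearing ones, which lay within the scatter of each other, but in this assay there is a 7.4-fold higher number from compound 3 to compound 4 (0.87 log units; beyond the scatter) and there is a 4.2-fold higher number from compound 2 to compound 4 (0.62 log units; beyond the scatter) once 3,5-difluorophenyl enters. The position therefore separates even 3-cyanophenyl and 3,5-difluorophenyl, two six-membered aromatic rings of carbon only with the same number of heavy atoms, and with a 2900-fold higher number from compound 1 to compound 4 (3.47 log units; beyond the scatter) as the widest gap of the set, compound 4 has the highest number, its steps to all the others being beyond the scatter. No measurement at hand accounts for this difference between the groups.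

On these data alone, whether a phenyl ring carrying a single fluoro group, a methoxy group or an amine would fall nearer compound 3 or compound 4 remains open. So does whether an ethyl group in place of the methyl on the pyrazole would keep the number of compound 1.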